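The compounds below may be only part of what the source reports. "The series", "measured", "known", "first", "only" and "open" are said of these compounds alone.

Three compounds that share one core were tested in an ADME assay on microsomes from liver (Mus musculus) for metabolic stability; on this read-out lower numbers stand for slow clearance and higher numbers for fast clearance. Compound 1 `CN1C(=O)C2=C(C1=O)N(CC(=O)Nc1ccc(-c3cccnc3)nc1)CCC2` gives 17 mL.min-1.g-1. Compound 2 `CN1C(=O)C2=C(C1=O)N(CC(=O)Nc1ccc(-c3ccccc3)nn1)CCC2` gives 36 mL.min-1.g-1. Compound 3 `CN1C(=O)C2=C(C1=O)N(CC(=O)Nc1ccc(-c3ccccn3)cc1)CCC2` gives 38 mL.min-1.g-1. Compound 3 and compound 2 lie within the usual scatter of each other in this assay, so no order between them can be read from these two numbers; compound 3 does stand clearly above compound 1, whose number is lower by more than the scatter.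

Compound 4 `CN1C(=O)C2=C(C1=O)N(CC(=O)Nc1ccc(-c3ccncc3)cc1)CCC2` has not yet been measured. It differs from compound 3 in one place: pyridin-4-yl in place of pyridin-2-yl on an aromatic carbon. The two compounds hold the same atoms, joined differently, so the change is a rearrangement rather than an addition or removal.

For the measured compounds named here, no measured pair here shows the effect of moving the ring nitrogen in this way, so the expectation rests on compound 3 alone. The step from compound 3 to compound 4 is expected to be small, a 1.2-fold lower number from compound 3 to compound 4 (0.06 log units; within the scatter), with no direction that stands beyond the scatter. Compound 4 is therefore estimated at 33 mL.min-1.g-1, within a range from 15 mL.min-1.g-1 to 70 mL.min-1.g-1.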

Compound 4, intrinsic clearance in microsomes: 44 mL.min-1.g-1
Estimate against measurement, compound 4: 1.3-fold (0.12 log units) below; low and high end bracket the measured number.
By their numbers in this assay, from the lowest: compound 1; then compounds 2, 3 and 4 (each within the scatter of the next).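

For the compounds shown here, compound 3 and compound 4 form the first pair here that differs in only one place, so they give the first direct look at this position, on an aromatic carbon of a six-membered aromatic ring of carbon only, para to a large group. In this assay, exchanging pyridin-2-yl for pyridin-4-yl gives a 1.2-fold higher number from compound 3 to compound 4 (0.06 log units; within the scatter), so on this read-out the two attachments of the pyridine ring cannot be told apart at this position. No supporting data bear on why the ring nitrogen can take either place with so little effect on the number.

Going by these compounds alone, this single pair covers only two pyridine rings at this position. On these data alone, how this assay would respond to a quite different group there, such as a carboxylic acid or a simple amine, remains open.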